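The compounds below may be only part of what the source reports. "The series", "measured", "known", "first", "only" and "open" are said of these compounds alone.

Series notes. The shared core carries an amino-linked ether chain that varies across the set. Compound 3 `COCNc1n[n+]([O-])c2ccccc2[n+]1[O-]` is the smallest member; in a functional assay on A549 cells (Homo sapiens) for cytotoxicity, read by MTT assay, with a stated time of 72 h (a higher number here means a weaker inhibitor, a lower number a stronger inhibitor), compound 3 gives 2770 nM. Of the three numbers this is the second highest. Compound 2 `O=[N+]([O-])c1cccc(COCNc2n[n+]([O-])c3ccccc3[n+]2[O-])c1` gives 3440 nM in this assay, a number within the scatter of that of compound 3, so the two cannot be ordered. Compound 1 `COc1ccc2c(c1)[n+]([O-])nc(NCOC(C)c1ccccc1)[n+]2[O-]` differs from compound 3 in several places at once. In this assay, among the compounds with values here, compound 1 gives 220 nM, a number beyond the scatter below that of compound 3; no single step to it is recorded, so its gap cannot be assigned to any one change.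

Compound 4 `CC(C)CCOCNc1n[n+]([O-])c2ccccc2[n+]1[O-]` has not been measured. It differs from compound 3 by isobutyl in place of hydrogen on a saturated chain carbon bound to an oxygen on a saturated carbon. Within the data shown here, no step between two measured compounds isolates a change of this kind, so there is nothing to calibrate it against; the only comparable extension of the chain, compound 2, gives a number indistinguishable from that of compound 3. The step is therefore expected to be modest, a 1.5-fold lower number from compound 3 to compound 4 (0.19 log units; within the scatter), leaning toward a lower number but possibly not beyond the scatter. Compound 4 is estimated at 1800 nM, with a range from 600 nM to 5000 nM.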

Compound 4, half-maximal inhibitory concentration: 2110 nM
Estimate against measurement, compound 4: 1.2-fold (0.07 log units) below, and the stated range covers the measured number.
By their numbers in this assay, from the lowest: compound 1; then compounds 4, 3 and 2 (each within the scatter of the next).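

Isobutyl in place of hydrogen on a saturated chain carbon bound to an oxygen on a saturated carbon gives, in this assay, a 1.3-fold lower number from compound 3 to compound 4 (0.12 log units; within the scatter), the first one-place step recorded in this series. At this position, a saturated chain of this size with no ring therefore leaves compound 4 and compound 3 indistinguishable in this read-out, so the step gives no ground for ordering them and shows that this change alone does not produce a separable difference. No measurement at hand bears on why the step reads this way.

Within the data shown here, still open is whether a group of a different kind on this same chain carbon, such as an amine, a carboxylic acid or a phenyl ring, would give a step beyond the scatter, as the only one-place step available here involves isobutyl. Also open, going by these compounds, is whether a longer chain than isobutyl would read the same in this assay, and whether the same change would read the same on the core of compound 1.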